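A few compounds are considered here, and "the series" means these few. Any claim that something is new, unique, unknown or untested is made for them only; others in the source may bear on it.

Measured so far:
- compound 1, `O=C(N/N=C/c1cccc(Cl)c1)c1cccnc1Nc1cccc(C(F)(F)F)c1`: 40.4%
- compound 2, `COc1cccc(/C=N/NC(=O)c2cccnc2Nc2cccc(C(F)(F)F)c2)c1`: 14.9%
- compound 3, `CNc1ncccc1C(=O)N/N=C/c1cccc(Cl)c1`: 40.4%

In a functional assay on the whole organism (strain Wistar) for inhibition, with Rattus norvegicus as the target, read by paw edema, with a stated time of 4 h, at a dose of 10 mg/kg by the intraperitoneal route (on this read-out higher numbers stand for more inhibition at the one dose given (going by the name of the read-out) and lower numbers for less inhibition), compound 1 gives 40.4%. Compound 2 is its single-point variant, (methoxy in place of chloro on an aromatic carbon), and with that change the read-out falls: a number 25.5 percentage points lower from compound 1 to compound 2 (beyond the scatter). Compound 3 rests on a different core; the difference between the core of compound 3 and the core of compound 1 is not broken down here. In this assay compound 3 gives 40.4%, level with compound 1 at the digits shown, a gap within the usual scatter, while against compound 2 the gap is beyond it. Compound 1 and compound 3 together hold the highest numbers of the three measured.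

Compound 4, `CNc1ncccc1C(=O)N/N=C/c1cccc(OC)c1`, has not yet been run in this assay. It differs from compound 3 by methoxy in place of chloro on an aromatic carbon, the same change at the same place as the one between the two measured variants of the first core. That change occurs twice among the compounds shown, and only once with a measured outcome. Going by the values given here, compound 3 starts from the same level as compound 1, so compound 4 is expected to drop by a step of about a number 24.4 percentage points lower from compound 3 to compound 4 (beyond the scatter), an expectation that rests on a number 25.5 percentage points lower from compound 1 to compound 2 (beyond the scatter) as the single comparable step. The transfer of a step measured on one core to another core is a guess with one data point behind it, and the range is set wide. Compound 4 is estimated at 16%, expected between 4% and 30%.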

Compound 4, a percentage reported as inhibition, in the whole organism at one dose (the size of the read-out at that dose, not a potency): 42.3%
The estimate for compound 4 lay 26.3 percentage points below the measured number; the measured number lies above the stated range.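

In this assay, the effect of methoxy in place of chloro on an aromatic carbon does not carry over from one core to the other: the same change on two cores in this assay, a number 25.5 percentage points lower (beyond the scatter) from compound 1 to compound 2 and a number 1.9 percentage points higher (within the scatter) from compound 3 to compound 4, 27.4 percentage points apart, beyond the scatter of two such steps. The drop seen with the 3-(trifluoromethyl)phenyl group on the nitrogen is therefore absent with methyl there, where the change gives a number 1.9 percentage points higher from compound 3 to compound 4 (within the scatter), while methyl in place of 3-(trifluoromethyl)phenyl with methoxy present gives a number 27.4 percentage points higher from compound 2 to compound 4 (beyond the scatter), so the outcome of the swap depends on the core in these two pairs. This rests on one pair per core at a single dose and time; it shows neither why the two cores differ nor how the swap would behave on any third core.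

The compounds shown leave open how a group such as a hydroxyl, an amine or a nitrile would read at that aromatic carbon on either core. They also leave open where the behaviour changes between the two nitrogen groups, for instance with an unsubstituted phenyl or a longer chain such as butyl on that nitrogen, paired with chloro and with methoxy.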